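Swapping 2-Methoxyphenyl for 3-Cyanopyridin-2-yl on a Ring Nitrogen

A few compounds are considered here, and "the series" means these few. Any claim that something is new, unique, unknown or untested is made for them only; others in the source may bear on it.

Of the compounds shown here, three of a shared core have been measured in a functional assay on HEK293 cells with D(4) dopamine receptor (Homo sapiens) as the target, read by FLIPR; a lower number here means a smaller maximal response, a higher number a larger maximal response. Compound 1 `O/N=C(\CCN1CCN(c2ccccn2)CC1)c1ccccc1` gives 70%. Compound 2 `O/N=C(/CCN1CCN(c2ccccn2)CC1)c1ccccc1Cl` gives 64%. Compound 3 `CCO/N=C(\CCN1CCN(c2ccccc2OC)CC1)c1ccccc1` gives 76%, the highest of the three numbers, though its gap to compound 1 lies within the usual scatter of repeated measurements, so the two cannot be ranked against each other. Only the gap to compound 2 lies beyond the scatter.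

Compound 4 `CCO/N=C(\CCN1CCN(c2ncccc2C#N)CC1)c1ccccc1` has not yet been measured. It differs from compound 3 in one place: 3-cyanopyridin-2-yl in place of 2-methoxyphenyl on an amine nitrogen in a ring.

Going by the values given here, no pair of measured compounds differs in exactly this way, so the size of the step cannot be read from a measured pair. A modest downward step is expected because compound 1 without the 2-methoxyphenyl gives 70% and because compound 2 without it gives 64%, both below compound 3. The step from compound 3 to compound 4 in this assay is therefore estimated at a number 10 percentage points lower from compound 3 to compound 4 (within the scatter), a change that may well stay within the scatter. For compound 4 the expected maximal response in this assay is 66%, with a likely range from 48% to 84%.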

Compound 4, largest response reached (reported as efficacy), in percent of the reference or control that the assay uses: 64%
Estimate against measurement, compound 4: 2 percentage points above; low and high end bracket the measured number.
By their numbers in this assay, from the lowest: compounds 2, 4, 1 and 3 (each within the scatter of the next, the first and the last beyond it).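

In this assay, going by these compounds alone, this swap gives the first single-place change that can be read, and it comes out as a number 12 percentage points lower from compound 3 to compound 4 (beyond the scatter). The earlier compounds shown here differ from one another in more than one place, so they could not show that the group on this amine nitrogen in a ring can shift the maximal response on its own while the rest of the molecule stays fixed; the response is lowered but not lost, as compound 4 still gives 64% in this assay. No measurement at hand explains the size or direction of this step.

The swap brings in a ring nitrogen and a nitrile at once, so the compounds shown cannot say which of the two goes with the step, and a plain phenyl or a 3-chloropyridin-2-yl on the same nitrogen would help to separate them. Within the data shown here, with only this one pair to read, it also stays open whether the same swap gives a similar step when another part of the molecule is changed.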